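Replacing 1H-pyrrol-2-yl with 1,2-thiazol-5-yl: an expected response

The compounds below may be only part of what the source reports. "The series", "measured", "known", "first", "only" and "open" are said of these compounds alone.

Compound 2 `c1c[nH]c(-c2ccccc2OCC2=NCCN2)c1`: 99%
Compound 1 `Cc1cccc(-c2ccccc2OCC2=NCCN2)n1`: 80%

In a functional assay with Alpha-1A adrenergic receptor (Homo sapiens) as the target, read by calcium flux (on this read-out higher numbers stand for larger maximal responses and lower numbers for smaller maximal responses), compound 2 gives the highest of the two numbers; its nearest neighbour, compound 1, gives 80%, a gap that lies beyond the usual scatter. Compound 3 `c1ccc(-c2ccns2)c(OCC2=NCCN2)c1` has not been measured. It differs from compound 2 in one place: 1,2-thiazol-5-yl in place of 1H-pyrrol-2-yl on an aromatic carbon. Among the compounds with values here, with only two measured compounds there is no measured step of this kind to lean on, so a modest decrease is expected, of a size near the edge of the scatter. Compound 3 is therefore estimated to give 85% in this assay, with a plausible range from 60% to 105%, an expected step of a number 14 percentage points lower from compound 2 to compound 3 (beyond the scatter).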

Compound 3, largest response reached (reported as maximum), in percent of the reference or control that the assay uses: 99%
Compound 3: middle estimate off by 14 percentage points, on the low side; the range from low to high includes it.
By their numbers in this assay, from the lowest: compound 1; then compounds 2 and 3 (each within the scatter of the next).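

Putting 1,2-thiazol-5-yl in place of 1H-pyrrol-2-yl on this aromatic carbon gives no change at the digits printed from compound 2 to compound 3 (within the scatter) in this assay. The hydrogen-bond donor of the 1H-pyrrol-2-yl ring is therefore not needed here to keep the maximal response, and a five-membered aromatic ring containing sulfur can take its place. Nothing available explains why the two rings behave alike. As far as these compounds go, it remains open how a plain phenyl ring at this place, or a 1,2-thiazol-5-yl ring carrying an amine or a carboxylic acid, would respond.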